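Ester to alcohol on the side chain

The compounds below may be only part of what the source reports. "The series", "measured", "known", "first", "only" and "open" are said of these compounds alone.

Values from a functional assay on A2780 cells (Homo sapiens) for antiproliferative activity, read by sulforhodamine B assay, with a stated time of 48 h (a higher number here means a weaker inhibitor of growth, a lower number a stronger inhibitor of growth), stand as follows
Compound 1 (`CC(C)(C)[Si](C)(C)O[C@@H]1CCCO[C@@H]1CO`) reads > 100000 nM as a limit
Compound 2 (`COC(=O)/C=C\[C@H]1OCCC[C@H]1O[Si](C)(C)C(C)(C)C`) reads 7300 nM as a number

For the measured compounds named here, compound 2 holds the only true number here, since the other value is a limit. Going by the values given here, the one measured step, an at least 13-fold lower number from compound 1 to compound 2 (1.13 log units; beyond the scatter), put 2-(methoxycarbonyl)ethenyl in place of hydroxymethyl and is large. Compound 3 (`CC(C)(C)[Si](C)(C)O[C@@H]1CCCO[C@@H]1/C=C\CO`) has hydroxymethyl in place of methoxycarbonyl on a double-bonded chain carbon bound to a double-bonded chain carbon. This brings a hydroxymethyl back, so part of that step may be lost, and a higher number beyond the scatter is expected in this assay for this change. The expected step is a 4.8-fold higher number from compound 2 to compound 3 (0.68 log units; beyond the scatter) by this estimate. For compound 3 the estimated value is 35000 nM with a range from 11000 nM to 100000 nM as expected.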

Compound 3, concentration for 50% growth inhibition: > 100000 nM
Compound 3 ended at the assay's limit (the forecaster's own chance of this, stated with the estimate: 35%); middle value at least 2.8-fold (0.45 log units) from the limit.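

In this assay, hydroxymethyl in place of methoxycarbonyl on a double-bonded chain carbon bound to a double-bonded chain carbon gives an at least 13-fold higher number from compound 2 to compound 3 (1.13 log units; beyond the scatter), so the double-bonded chain alone does not keep the reading of compound 2. Compound 3 gives > 100000 nM, which is a limit. The step from compound 1 to compound 3 cannot be read, and this limit recurs across the set: the limit of > 100000 nM in this assay, at which 2 of the 3 values shown sit.

The compounds shown leave open whether a carboxylic acid or an amide on that chain carbon would keep a reading like that of compound 2. They also leave open the true value of compound 3.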